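This account rests on a few compounds, and the source may have more. Where it says the series, first, only, none or still open, it means among the compounds named here.

Measured compounds in an ADME assay on MRC5 cells (Homo sapiens), read by MTT assay, with a stated time of 72 h; on this read-out higher numbers stand for weaker inhibition and lower numbers for stronger inhibition:

compound 1 `COc1ncnc2c1c(-c1ccsc1)cn2[C@@H]1O[C@H](CO)[C@@H](O)[C@H]1O`: 75300 nM
compound 2 `COc1ncnc2c1c(-c1cccs1)cn2[C@@H]1O[C@H](CO)[C@@H](O)[C@H]1O`: 43200 nM
compound 3 `CNc1ncnc2c1c(-c1cccs1)cn2[C@@H]1O[C@H](CO)[C@@H](O)[C@H]1O`: a limit, > 100000 nM

Compound 2 and compound 1 differ by thiophen-3-yl in place of thiophen-2-yl on an aromatic carbon, which gave a 1.7-fold higher number from compound 2 to compound 1 (0.24 log units; within the scatter). Compound 2 and compound 3 differ by methylamino in place of methoxy on an aromatic carbon, which gave an at least 2.3-fold higher number from compound 2 to compound 3 (0.36 log units; beyond the scatter). For compound 3 the read-out in this assay is a limit only, (the limit of > 100000 nM in this assay, at which 1 of the 3 values shown sits). Compound 4 `CNc1ncnc2c1c(-c1ccsc1)cn2[C@@H]1O[C@H](CO)[C@@H](O)[C@H]1O` has not yet been measured in this assay. It differs from compound 3 by thiophen-3-yl in place of thiophen-2-yl on an aromatic carbon, the same change as from compound 2 to compound 1 on the same kind of place; the two cores differ by methylamino in place of methoxy on an aromatic carbon. The step from compound 3 to compound 4 is expected to be a step that the limit leaves unreadable from compound 3 to compound 4, beside a 1.7-fold higher number from compound 2 to compound 1 (0.24 log units; within the scatter), because the earlier step of a 1.7-fold higher number from compound 2 to compound 1 (0.24 log units; within the scatter) stayed within the scatter. Compound 4 is therefore estimated at about 170000 nM in this assay, most likely reported again as a limit.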

Compound 4, half-maximal inhibitory concentration: > 100000 nM
Compound 4: no number, only a limit; the forecaster's own chance of this, stated with the estimate: 80%; the middle value is on the limit's open side.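

In this assay compound 4 gives > 100000 nM, which is a limit and not a number, so the steps that depend on comparing it with the limit of compound 3 cannot be read. Methylamino in place of methoxy on the thiophen-3-yl core gives an at least 1.3-fold higher number from compound 1 to compound 4 (0.12 log units; that floor lies within the scatter) and, set beside the thiophen-2-yl core, the change reads as follows: the same change on two cores in this assay, an at least 2.3-fold higher number (0.36 log units; beyond the scatter) from compound 2 to compound 3 and an at least 1.3-fold higher number (0.12 log units; that floor lies within the scatter) from compound 1 to compound 4; the limit leaves it open whether they differ. The higher number is therefore consistent across both cores only as a floor, and neither its size on the second core nor the effect of thiophen-3-yl on the methylamino core is shown.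

Still open, on these data alone, is how an unsubstituted amine or a longer alkoxy chain on that aromatic carbon would read in this assay, and whether either would give a number rather than a limit.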